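A Larger Ring-Bearing Chain on Compound 1

The source may hold more compounds than are shown below. What is called first, only, known or untested is meant among the compounds shown, and "the series" means these compounds.

compound 1 `CCCn1c(=O)c(S(=O)(=O)c2ccc(F)cc2F)cc2cnc(Nc3ccc4[nH]ccc4c3)nc21`: 1000 nM
compound 2 `Cn1c(=O)c(S(=O)(=O)c2ccc(F)cc2F)cc2cnc(Nc3cccc4[nH]ccc34)nc21`: 1500 nM
compound 3 `Cn1c(=O)c(S(=O)(=O)c2ccccc2)cc2cnc(Nc3cnc4[nH]ccc4c3)nc21`: 5000 nM

In a functional assay on K562 cells (Homo sapiens) for inhibition, read by trypan blue exclusion, with a stated time of 72 h (a lower number here means a stronger inhibitor, a higher number a weaker inhibitor), compound 1 (at 1000 nM) and compound 2 (at 1500 nM) lie within the scatter of each other, while compound 3 (at 5000 nM) reads higher than compound 1 by more than the scatter. Compound 4 `O=c1c(S(=O)(=O)c2ccc(F)cc2F)cc2cnc(Nc3ccc4[nH]ccc4c3)nc2n1CC1CCCC1` differs from compound 1 by cyclopentyl in place of ethyl on a saturated chain carbon bound to an aromatic nitrogen. Among the compounds with values here, no measured pair isolates a change at this place, so no step beyond the scatter is expected in this assay, in either direction. The expected result is no change at the digits printed from compound 1 to compound 4 (within the scatter). Compound 4 is estimated at 1000 nM, within an expected range of 300 nM to 3500 nM.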

Compound 4, half-maximal inhibitory concentration: 7000 nM
Beside the measured number, compound 4's estimate is 7.0-fold (0.85 log units) below it; the measured number lies above the stated range.
By their numbers in this assay, from the lowest: compounds 1 and 2 (each within the scatter of the next); then compounds 3 and 4 (each within the scatter of the next).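

In this assay, within the data shown here, the earlier compounds offered no single-place step, and this pair gives the first: cyclopentyl in place of ethyl on a saturated chain carbon bound to an aromatic nitrogen brings a 7.0-fold higher number from compound 1 to compound 4 (0.85 log units; beyond the scatter) and so a weaker inhibitor. The position therefore does not accept every group, and what enters here matters to inhibition. The data offer no explanation for this step.

Going by these compounds, whether an open chain such as butyl or pentyl would read like compound 1 or like compound 4 remains open. So does the reading of a smaller ring, such as cyclopropylmethyl, or of a chain ending in an amine.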